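The source may hold more compounds than are shown below. What is called first, only, known or untested is meant among the compounds shown, and "the series" means these compounds.

Two compounds have so far been measured in a functional assay on A549 cells (Homo sapiens) for antiproliferative activity, read by CCK-8 assay, with a stated time of 72 h; on this read-out lower numbers stand for stronger inhibition and higher numbers for weaker inhibition:

Compound 1, `O=C(Nc1cccc(-c2oc3cc(-c4ccc(F)cc4)ccc3c(=O)c2O)c1)c1ccccc1F`: 4410 nM
Compound 2, `O=C(Nc1cccc(-c2oc3cc(-c4ccc(F)cc4)ccc3c(=O)c2O)c1)c1ccc(Cl)nc1`: 3580 nM

Among the measured compounds shown here, compound 2 holds the lowest of the two numbers, though its only neighbour, compound 1, is separated from it by no more than a 1.2-fold lower number from compound 1 to compound 2 (0.09 log units; within the scatter), a gap within the scatter of the measurement. The next compound, compound 3, `O=C(Nc1cccc(-c2oc3cc(-c4ccc(F)cc4)ccc3c(=O)c2O)c1)c1ccc([N+](=O)[O-])cc1`, is reached from compound 2 by a single change: 4-nitrophenyl in place of 6-chloropyridin-3-yl on a carbonyl carbon.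

For the measured compounds named here, the one measured step that bears on this change is the earlier exchange of the aryl group on the same carbonyl carbon, a 1.2-fold lower number from compound 1 to compound 2 (0.09 log units; within the scatter), which left the activity essentially where it was. Going by the values given here, with only that step as a guide, and no measurement yet of a nitro-bearing group, the expected outcome for compound 3 is again a step that does not clear the scatter, a 1.1-fold higher number from compound 2 to compound 3 (0.05 log units; within the scatter), in either direction. Compound 3 is therefore estimated at 4000 nM in this assay, with a range from 1500 nM to 11000 nM.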

Compound 3, half-maximal inhibitory concentration: 2440 nM
Estimate against measurement, compound 3: 1.6-fold (0.21 log units) above; the range from low to high includes it.
By their numbers in this assay, from the lowest: compounds 3, 2 and 1 (each within the scatter of the next).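

With compound 3, the aryl group on the carbonyl carbon has now been varied a second time, with a ring of carbon only bearing a nitro group replacing a ring with a hetero atom. In this assay, this exchange gives a 1.5-fold lower number from compound 2 to compound 3 (0.17 log units; within the scatter), and the comparison with the 2-fluorophenyl group gives a 1.8-fold lower number from compound 1 to compound 3 (0.26 log units; within the scatter), so all three aryl groups at this place remain within the scatter of one another and the change in ring type and substituent registers no clear effect on the read-out. Nothing available accounts for this flat response.

The three compounds all keep an aromatic ring on this carbonyl carbon, so they leave open whether a ring bearing an amine or a carboxylic acid, or a simple alkyl chain in place of the ring, would move the number beyond the scatter. They also leave open whether the 4-fluorophenyl group and the hydroxyl group on the shared core, both unchanged here, have more influence on activity in this assay than the group on the carbonyl carbon.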